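This account rests on a few compounds, and the source may have more. Where it says the series, first, only, none or still open, it means among the compounds named here.

Measured compounds and values in an ADME assay on HEp-2 cells (Homo sapiens) for cytotoxicity, with a stated time of 4 days; on this read-out higher numbers stand for lower toxicity in this test and lower numbers for higher toxicity in this test:

compound 1 `CS(=O)(=O)CCCn1c(Cn2cc(S(C)(=O)=O)c3ccncc32)nc2cc(Cl)ccc21` — > 100000 nM (a limit of the assay, not a number)
compound 2 `CC(C)S(=O)(=O)c1cn(Cc2nc3cc(Cl)ccc3n2CCCS(C)(=O)=O)c2ccccc12` — > 100000 nM (a limit)
compound 3 `CS(=O)(=O)c1nn(Cc2nc3cc(Cl)ccc3n2CCO)c2cnccc12` — > 100000 nM (a limit)

Compound 3 stands where every measured member of the series stands: at the limit, as shown by the limit of > 100000 nM in this assay, at which 3 of the 3 values shown sit. Going by the values given here, no value in this assay is a number, so no step between measured compounds can be sized, and compound 3 can be placed neither above nor below compound 1 or compound 2; all that is known is that each of them sits at the same limit.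

Compound 4 `CS(=O)(=O)c1nn(Cc2nc3cc(Cl)ccc3n2CCC(F)(F)F)c2cnccc12` is not yet measured. It differs from compound 3 by trifluoromethyl in place of hydroxy on a saturated chain carbon, two bonds along the chain from an aromatic nitrogen. The change exchanges a hydroxy for a trifluoromethyl on the saturated chain carbon two bonds along the chain from the aromatic nitrogen; the rest of the structure is unchanged.

Among the compounds with values here, with all three measured values sitting at the limit, no step in this assay has been observed, and there is no basis for expecting one beyond the scatter from compound 3 to compound 4. The step from compound 3 to compound 4 is therefore expected to be a number no higher from compound 3 to compound 4 (the limit leaves the size open), that is, none beyond the scatter. Compound 4 is expected to give 100000 nM in this assay, in the range 40000 nM to 300000 nM, most likely again reported only as the same limit.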

Compound 4, half-maximal cytotoxic concentration: > 100000 nM
Compound 4: only a limit was reported (the forecaster's own chance of this, stated with the estimate: 75%); the middle value lies on the limit itself.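

In this assay compound 4 gives > 100000 nM, a limit and not a number. Compound 3 also carries only a limit, so no step can be read between compound 3 and compound 4. The compounds shown leave open at what concentration, if any, a member of this series turns cytotoxic in this assay, and whether trifluoromethyl in place of hydroxy alters that concentration.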